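Swapping amino for nitro on the shared core

This account rests on a few compounds, and the source may have more. Where it says the series, first, only, none or still open, it means among the compounds named here.

- compound 1 `COc1cc(-n2cnc3ccc(-c4ccc([N+](=O)[O-])cc4)cc32)cc(OC)c1OC` measured at 79 nM
- compound 2 `COc1cc(-n2cnc3ccc(-c4cccc(N)c4)cc32)cc(OC)c1OC` measured at 21 nM

In a functional assay on SGC-7901 cells (Homo sapiens) for antiproliferative activity, read by MTT assay, with a stated time of 72 h (on this read-out higher numbers stand for weaker inhibition and lower numbers for stronger inhibition), compound 2 (21 nM) holds the lower of the two numbers, and compound 1 sits above it by a gap beyond the scatter. The next compound, compound 3 `COc1cc(-n2cnc3ccc(-c4cccc([N+](=O)[O-])c4)cc32)cc(OC)c1OC`, has nitro in place of amino on an aromatic carbon, meta to a large group (nitro in place of amino on an aromatic carbon). Going by the values given here, only one measured step bears on this change (a 3.8-fold lower number from compound 1 to compound 2 (0.58 log units; beyond the scatter)). That step is modest, and it swapped 4-nitrophenyl for 3-aminophenyl, so group and place changed together and the data cannot separate them. Among the compounds with values here, compound 3 keeps the place of the group in compound 2 but carries the nitro of compound 1 (79 nM), the only measured compound with that group. A move back towards a higher number in this assay is therefore expected, of similar or slightly smaller size (a 2.6-fold higher number from compound 2 to compound 3 (0.42 log units; beyond the scatter)), though it may prove small. For compound 3 the estimated value is 55 nM, with an expected range from 18 nM to 170 nM at its upper end.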

Compound 3, half-maximal inhibitory concentration: 380 nM
Compound 3: middle estimate off by 6.9-fold (0.84 log units), on the low side, and the stated range ends below it.
By their numbers in this assay, from the lowest: compound 2; then compound 1; then compound 3.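

At the place held by compound 2 and compound 3, meta to a large group, nitro in place of amino gives an 18-fold higher number from compound 2 to compound 3 (1.26 log units; beyond the scatter) in this assay, so the identity of the group alone accounts for a large step. With the nitro kept, 3-nitrophenyl in place of 4-nitrophenyl gives a 4.8-fold higher number from compound 1 to compound 3 (0.68 log units; beyond the scatter), so the place of the group also matters. Group and place, which changed together in the first step, can now be read apart: among the two nitro compounds, the 4-nitrophenyl of compound 1 has the lower number, while at the shared place the amino of compound 2 has a far lower number than the nitro of compound 3.

Nothing available explains why the two groups differ so widely at this place. The compounds shown leave open how a 4-aminophenyl would compare with the 4-nitrophenyl of compound 1, and whether a hydroxyl or an acetamide at the shared place would stand closer to amino or to nitro.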